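The source may hold more compounds than are shown below. What is called first, only, known or untested is meant among the compounds shown, and "the series" means these compounds.

Measured compounds in an assay on isolated protein for inhibition of Aromatase (Homo sapiens), read by fluorescence; on this read-out lower numbers stand for stronger inhibition and higher numbers for weaker inhibition:
compound 1 `N#Cc1ccc(-n2ccc3ccncc32)cc1Oc1ccccc1` gives 114 nM
compound 2 `Cc1cc(-n2ccc3ccncc32)ccc1Cl` gives 59 nM
compound 3 `N#Cc1ccc(Oc2cccnc2)cc1Oc1cccnc1` gives 304 nM

Compound 1 stands second highest of the three numbers in this assay. Its nearest is compound 2, whose value lies within the scatter of repeated measurement of the value of compound 1, so the two are not separable here. Compound 3 sits furthest away, with a higher number that lies beyond the scatter; those two structures differ in more than one place, so no single change can be read from that pair. Among the compounds with values here, no step between measured compounds that differ in one place is available, and nothing among the measured compounds isolates the contribution of the phenoxy group.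

Compound 4 `N#Cc1ccc(-n2ccc3ccncc32)cc1` is the next compound to be measured in this assay. It differs from compound 1 as follows: hydrogen in place of phenoxy on an aromatic carbon. Whether the phenoxy group carries weight for inhibition is not told by any measured pair. A modest weakening is expected, the estimated step from compound 1 to compound 4 being a 1.8-fold higher number from compound 1 to compound 4 (0.24 log units; within the scatter), which may not clear the scatter. Compound 4 is accordingly estimated at 200 nM, with a range from 60 nM to 700 nM.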

Compound 4, half-maximal inhibitory concentration: 93 nM
The estimate for compound 4 lay 2.2-fold (0.33 log units) above the measured number; measured number inside the range.
By their numbers in this assay, from the lowest: compounds 2, 4 and 1 (each within the scatter of the next); then compound 3.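

In this assay, within the data shown here, hydrogen in place of phenoxy on an aromatic carbon, ortho to a cyano group, gives a 1.2-fold lower number from compound 1 to compound 4 (0.09 log units; within the scatter), the first comparison that isolates a change in one place. The phenoxy group, with its 7 heavy atoms and one six-membered aromatic ring of carbon only, can therefore be removed from this position of the shared core without a difference that this read-out can resolve, so compound 1 and compound 4 are not separable and the added bulk of phenoxy brings no measurable gain in inhibition here. Nothing available explains why this position accepts either hydrogen or phenoxy.

Going by these compounds, only these two substituents can be compared at this position, so it remains open whether methoxy, an amine, a carboxylic acid or a longer chain on the same carbon would leave the read-out unchanged or move it beyond the scatter. Among these compounds, the contribution of the cyano group also remains open, as no pair differing in one place isolates it, and this single step cannot show whether the same result would hold on another core.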